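The compounds below may be only part of what the source reports. "The series", "measured", "known", "first", "only" and "open" are said of these compounds alone.

Notes on the series. Compound 1 `O=C(c1ccc(Cl)cc1)c1ccc2c(c1)oc(=O)n2C(=O)NCCCCc1ccccc1` gives 14 nM in an assay on HEK293 cells for inhibition of acid ceramidase (Homo sapiens), with a stated time of 10 min; on this read-out higher numbers stand for weaker inhibition and lower numbers for stronger inhibition. Compound 2 `O=C(NCCCCc1ccccc1)n1c(=O)oc2ccc(F)cc21` gives 12 nM in this assay, and compound 3 `O=C(NCCCCc1ccc(F)cc1)n1c(=O)oc2ccccc21` gives 75 nM. Compound 1 thus holds the second highest of the three numbers: its value and that of compound 2 fall within the scatter of each other, whereas compound 3 sits at a larger number, beyond the scatter. Compound 4 `O=C(NCCCCc1ccccc1)n1c(=O)oc2cc(Br)ccc21` has not yet been measured in this assay. It differs from compound 1 as follows: bromo in place of (4-chlorophenyl)carbonyl on an aromatic carbon. Going by the values given here, no pair of measured compounds isolates this change. Compound 2 carries a single halogen on the core without a (4-chlorophenyl)carbonyl and gives 12 nM, close to compound 1, so only a modest shift, likely not beyond the scatter, is expected in this assay. Compound 4 is expected to give 20 nM, in the range 6 nM to 70 nM. This corresponds to an expected 1.4-fold higher number from compound 1 to compound 4 (0.15 log units; within the scatter).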

Compound 4, half-maximal inhibitory concentration: 31 nM
Compound 4: the middle estimate sits 1.6-fold (0.19 log units) below what was measured; the range from low to high includes it.
By their numbers in this assay, from the lowest: compounds 2 and 1 (each within the scatter of the next); then compound 4; then compound 3.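

In this assay, bromo in place of (4-chlorophenyl)carbonyl on this aromatic carbon gives a 2.2-fold higher number from compound 1 to compound 4 (0.35 log units; beyond the scatter) and is a modest step beyond the scatter. This aromatic carbon therefore accepts both a single bromine and the much larger (4-chlorophenyl)carbonyl with its six-membered aromatic ring, at only a modest cost for the smaller group. Nothing at hand gives a reason for this step. Open, going by these compounds, is how an amine or a carboxylic acid on this aromatic carbon would compare with bromo. Also open, on these data alone, is how a plain phenylcarbonyl would compare with (4-chlorophenyl)carbonyl.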